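Series notes: benzyl against directly attached aryl

This account rests on a few compounds, and the source may have more. Where it says the series, first, only, none or still open, it means among the compounds named here.

In a functional assay on CCRF-CEM cells (Homo sapiens) for inhibition, read by cell counting, with a stated time of 3 days (on this read-out lower numbers stand for stronger inhibition and higher numbers for weaker inhibition), compound 3 `C=C(Br)C(=O)Nc1cccc(-c2cn3nc(-c4ccc(OC)c(OC)c4)sc3n2)c1` gives 380 nM, the lowest of the three numbers; compound 2 `C=C(Br)C(=O)Nc1cccc(-c2cn3nc(-c4ccc(C)cc4)sc3n2)c1` gives 1700 nM and compound 1 `C=C(Br)C(=O)Nc1cccc(-c2cn3nc(Cc4ccccc4)sc3n2)c1` gives 4200 nM. Compound 4 `C=C(Br)C(=O)Nc1cccc(-c2cn3nc(Cc4ccc(OC)cc4)sc3n2)c1` carries 4-methoxybenzyl in place of 3,4-dimethoxyphenyl on an aromatic carbon. Within the data shown here, two measured steps bear on this change: an 11-fold lower number from compound 1 to compound 3 (1.04 log units; beyond the scatter) and a 2.5-fold lower number from compound 1 to compound 2 (0.39 log units; beyond the scatter), both replacing a benzyl by a directly attached aryl and both lowering the number; a 4.5-fold lower number from compound 2 to compound 3 (0.65 log units; beyond the scatter) separates the two aryl variants. Among the measured compounds shown here, compound 4 returns to a benzyl link, so a higher number than for compound 3 is expected, though 4-methoxybenzyl itself has no measured precedent in this set. Compound 4 is estimated at 2000 nM in this assay, with a range of 700 nM to 6000 nM, which would mean a 5.3-fold higher number from compound 3 to compound 4 (0.72 log units; beyond the scatter).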

Compound 4, half-maximal inhibitory concentration: 2300 nM
The estimate for compound 4 lay 1.2-fold (0.06 log units) below the measured number; measured number inside the range.
By their numbers in this assay, from the lowest: compound 3; then compounds 2, 4 and 1 (each within the scatter of the next, the first and the last beyond it).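

In this assay, a methoxy on the benzyl ring does not recover the low number of the directly attached 3,4-dimethoxyphenyl (a 6.1-fold higher number from compound 3 to compound 4 (0.78 log units; beyond the scatter)). That methoxy leaves compound 4 within the scatter of the plain benzyl (a 1.8-fold lower number from compound 1 to compound 4 (0.26 log units; within the scatter)), and the 4-methoxybenzyl and 4-methylphenyl groups are not separated here either (a 1.4-fold higher number from compound 2 to compound 4 (0.13 log units; within the scatter)). No available evidence gives a reason for these steps.

The direct link and the second methoxy remain unseparated, as compound 3 and compound 4 differ in both. Going by these compounds, how an amine or a longer chain at this position would read also remains open.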